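This account rests on a few compounds, and the source may have more. Where it says the series, first, only, none or still open, it means among the compounds named here.

Measured so far:
- compound 1 `CC[C@H](C)[C@H](N)CN(C(=O)[C@@H]1C[C@H]1c1ccccc1)c1ccc(-c2ccc(OC)cc2)cc1` — in a functional assay for agonist activity at G protein-coupled receptor 88 (Homo sapiens), read by HTRF and cAMP accumulation (a lower number here means that less compound is needed, a higher number that more compound is needed for the effect), compound 1 gives 120 nM
- compound 2 `CC[C@H](C)[C@H](N)CN(C(=O)[C@@H]1C[C@H]1c1ccccc1)c1ccc(-c2ccc(CO)cc2)cc1` — in this assay compound 2 gives 1100 nM

Compound 2 has the highest of the two numbers; its nearest neighbour is compound 1, and the step of a 9.2-fold higher number from compound 1 to compound 2 (0.96 log units; beyond the scatter) lies beyond the scatter. Compound 3 `CC[C@H](C)[C@H](N)CN(C(=O)[C@@H]1C[C@H]1c1ccccc1)c1ccc(-c2ccc(CCC(=O)OC)cc2)cc1` is not yet measured. It differs from compound 2 by (methoxycarbonyl)methyl in place of hydroxy on a saturated chain carbon bound to an aromatic carbon. Within the data shown here, the only measured step that bears on this position is the one from compound 1 to compound 2, which replaced methoxy with hydroxymethyl and moved the number by a 9.2-fold higher number from compound 1 to compound 2 (0.96 log units; beyond the scatter); it shows that the substituent at this position matters, but the new group of compound 3 is not among those measured, so the direction is uncertain. A step of roughly the measured size, in either direction, is expected. For compound 3 a value of 500 nM is estimated, within 120 nM to 2500 nM, a step of a 2.2-fold lower number from compound 2 to compound 3 (0.34 log units; beyond the scatter) expected from compound 2.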

Compound 3, half-maximal effective concentration: 110 nM
Beside the measured number, compound 3's estimate is 4.5-fold (0.66 log units) above it, and the stated range ends above it.
By their numbers in this assay, from the lowest: compounds 3 and 1 (each within the scatter of the next); then compound 2.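

The change from hydroxymethyl to 2-(methoxycarbonyl)ethyl in this assay gives a 10-fold lower number from compound 2 to compound 3 (1.00 log units; beyond the scatter) and shows that this position accepts a much larger group without a higher number. Replacing methoxy with 2-(methoxycarbonyl)ethyl gives a 1.1-fold lower number from compound 1 to compound 3 (0.04 log units; within the scatter) and the two groups cannot be told apart here, so the size of the substituent does not set the number across these compounds; of the three, only compound 2 carries a hydroxy group, and only compound 2 stands apart. Nothing available explains these differences.

Still open, on these data alone, is whether the ester matters or the chain alone is enough, a question that a plain propyl chain or the free carboxylic acid would address. As far as these compounds go, the response to an amine at the chain end, or to a longer chain, also remains unknown.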